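Replacing the aryl group on a succinimide-bearing piperazine amide

The source may report more compounds than this note shows. Statements on the series, on what has been measured and on what is new or still open speak of the compounds shown alone.

Compound 1 `CC(C(=O)N1CCN(c2ccc(F)cc2)CC1)N1C(=O)CCC1=O` was tested in a functional assay on the whole organism (strain Swiss) with Mus musculus as the target, in the maximal electroshock model, with a stated time of 2 h, at a dose of 300 mg/kg by the intraperitoneal route (a higher number here means a stronger effect of the compound at the dose given, a lower number a weaker effect), where compound 1 gives 50%. Among the two measured compounds it holds the highest number, with compound 2 `CC(C(=O)N1CCN(c2ccc(C(F)(F)F)cc2)CC1)N1C(=O)CCC1=O` as its nearest neighbour; in this assay compound 2 gives 0%. For the measured compounds named here, the single measured step, a number 50 percentage points lower from compound 1 to compound 2 (beyond the scatter), arises from trifluoromethyl in place of fluoro on an aromatic carbon and shows that exchanging the substituent on the aryl ring can move the read-out a long way.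

Compound 3 `CC(C(=O)N1CCN(c2ccccc2Cl)CC1)N1C(=O)CCC1=O` differs from compound 1 by 2-chlorophenyl in place of 4-fluorophenyl on an amine nitrogen in a ring. Going by the values given here, no measured step covers this particular exchange; the one step available concerns a different group on the same ring, and it points downward. Among the compounds with values here, with only that to lean on, compound 3 is expected to stay at or somewhat below compound 1, with a wide range because the sole comparison, a number 50 percentage points lower from compound 1 to compound 2 (beyond the scatter), involves another substituent. The estimated step is a number 15 percentage points lower from compound 1 to compound 3 (beyond the scatter). For compound 3 in this assay the expected value is 35%, ranging from 0% to 75%.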

Compound 3, a percentage reported as activity, at one dose (the size of the read-out at that dose, not a potency): 0%
Compound 3: the middle estimate sits 35 percentage points above what was measured, within the range that was stated.
By their numbers in this assay, from the lowest: compounds 2 and 3 (each within the scatter of the next); then compound 1.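

The step of a number 50 percentage points lower from compound 1 to compound 3 (beyond the scatter) shows that in this assay a large drop at this position does not depend on trifluoromethyl, as it also appears with 2-chlorophenyl in place of 4-fluorophenyl on the amine nitrogen in the ring. Two different exchanges on the aryl group now end at the same printed number, with compound 2 at 0% and compound 3 at 0%, so among these three compounds only compound 1, at 50%, keeps any effect at the dose given. Nothing measured here accounts for the drop with 2-chlorophenyl, and no explanation can be drawn from these data.

This exchange alters both the halogen and where it stands on the aryl ring, and the compounds shown cannot separate those two changes. Also open, going by these compounds, is how the read-out would respond to a phenyl ring carrying no halogen, or to a methoxy group or a methyl group on that ring, and whether any group other than fluorine can retain the effect seen with compound 1.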